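Isopropyl for cyclopentyl on an antiproliferative compound

The source may hold more compounds than are shown below. What is called first, only, known or untested is meant among the compounds shown, and "the series" means these compounds.

- Compound 1 `N=C(NC(=N)NC1CCCC1)Nc1ccc(C(F)(F)F)cc1` gives 1800 nM here
- Compound 2 `CC(C)CNC(=N)NC(=N)Nc1ccc(F)cc1F` gives 3600 nM here

Going by the values given here, in a functional assay on A549 cells (Homo sapiens) for antiproliferative activity, read by MTT assay, with a stated time of 72 h (on this read-out lower numbers stand for stronger inhibition and higher numbers for weaker inhibition), compound 1 gives 1800 nM and compound 2 gives 3600 nM as the only other number. Among the compounds with values here, these two values lie within the usual scatter of each other, so compound 1 cannot be separated from compound 2 on the numbers so far.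

Compound 3 `CC(C)NC(=N)NC(=N)Nc1ccc(C(F)(F)F)cc1` keeps the core of compound 1 and alters one group: isopropyl in place of cyclopentyl on an amine nitrogen with the rest unchanged. Within the data shown here, no measured pair shows this change on its own, so the data offer no direct guide. A small rise in the number in this assay is expected, meaning somewhat weaker inhibition, at about the edge of the scatter. The expected step of a 1.9-fold higher number from compound 1 to compound 3 (0.29 log units; within the scatter) is only an estimate. Compound 3 is estimated at 3500 nM with an expected range from 1500 nM to 8000 nM in this measurement.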

Compound 3, half-maximal inhibitory concentration: 3600 nM
For compound 3 the middle estimate is 1.0-fold (0.01 log units) below the measured one; measured number inside the range.
By their numbers in this assay, from the lowest: compounds 1, 2 and 3 (each within the scatter of the next).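

Going by these compounds alone, compound 1 and compound 3 form the first pair that differs in one place, and in this assay the change of cyclopentyl to isopropyl on an amine nitrogen gives a 2.0-fold higher number from compound 1 to compound 3 (0.30 log units; within the scatter) with the rest of the structure unchanged. At this position, then, the five-membered non-aromatic ring of carbon only and the open isopropyl group cannot be told apart on this read-out, so the ring shows no measurable contribution to the number here. No measured information bears on why these two groups read alike.

On these data alone, whether a longer chain, an amine or a carboxylic acid at this place would move the number beyond the scatter remains open. Compound 2 differs from compound 1 and from compound 3 in more than one place, so the contribution of its other groups cannot be read from these values.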